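The source may report more compounds than this note shows. Statements on the series, on what has been measured and on what is new or still open speak of the compounds shown alone.

The account follows compound 3, whose structure is `COC(=O)CCNC1=CS(=O)(=O)O[C@@]12[C@@H](CO[Si](C)(C)C(C)(C)C)O[C@@H](n1cc(C)c(=O)n(C)c1=O)[C@@H]2O[Si](C)(C)C(C)(C)C`, to compound 4, whose structure is `Cc1cn([C@@H]2O[C@H](CO[Si](C)(C)C(C)(C)C)[C@@]3(OS(=O)(=O)C=C3NCC(=O)C(=O)O)[C@H]2O[Si](C)(C)C(C)(C)C)c(=O)n(C)c1=O`. In a functional assay on HEL cells (Homo sapiens) for cytotoxicity, read by microscopy (a lower number here means that less compound is tolerated, a higher number that more compound is tolerated), compound 3 gives >= 400000 nM, which is a limit of the assay and not a number. Compound 1, with structure `COC(=O)C(=O)CNC1=CS(=O)(=O)O[C@@]12[C@@H](CO[Si](C)(C)C(C)(C)C)O[C@@H](n1cc(C)c(=O)n(C)c1=O)[C@@H]2O[Si](C)(C)C(C)(C)C`, gives in this assay a value of > 400000 nM, again a limit. Compound 2, with structure `Cc1cn([C@@H]2O[C@@H]3COC(=O)[C@]3(OS(C)(=O)=O)[C@H]2O)c(=O)[nH]c1=O`, gives in this assay a value of >= 400000 nM, also a limit. Within the data shown here, all three measured values therefore sit at the limit of > 400000 nM in this assay, at which 1 of the 3 values shown sits, or at the limit of >= 400000 nM in this assay, at which 2 of the 3 values shown sit, and the one step between compounds differing in a single place, a step that the two limits leave unreadable from compound 1 to compound 3, cannot be read in size or direction. The change to compound 4 is carboxycarbonyl in place of (methoxycarbonyl)methyl on a saturated chain carbon bound to an amine nitrogen. Among the measured compounds shown here, no measured step bears on this change, and the neighbouring step from compound 1 to compound 3 was unreadable. Compound 4 is therefore expected in this assay to give 400000 nM, with a range from 130000 nM to 400000 nM. The expected step is a number no higher from compound 3 to compound 4 (the limit leaves the size open), no change beyond the scatter.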

Compound 4, minimum cytotoxic concentration: 400000 nM
Beside the measured number, compound 4's estimate shows no gap at the digits printed; the range from low to high includes it.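

In this assay compound 4 gives 400000 nM, the only plain number among the compounds shown, with carboxycarbonyl on a saturated chain carbon bound to an amine nitrogen. The record for this change reads as a number no higher from compound 3 to compound 4 (the limit leaves the size open), and the loss of the methyl on the oxygen next to a carbonyl group reads as a number no higher from compound 1 to compound 4 (the limit leaves the size open). Neither step can be read in size, because both start from a compound that rests on a limit of the assay: the limit of > 400000 nM in this assay, at which 1 of the 4 values shown sits.

The compounds shown leave open whether any group at this place would give a number clearly lower in this assay. An amide or an amine in place of carboxycarbonyl, or a longer chain, would test that on the same core.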